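From bromo to nitro on a shared core

A few compounds are considered here, and "the series" means these few. Any claim that something is new, unique, unknown or untested is made for them only; others in the source may bear on it.

Going by the values given here, only two compounds have numbers so far. In a functional assay on PANC-1 cells (Homo sapiens) for antiproliferative activity, read by fluorescence and resazurin assay, with a stated time of 48 h (a lower number here means a stronger inhibitor, a higher number a weaker inhibitor), compound 2 (`O=C(N/N=C/c1cc2ccccc2nc1Cl)c1cc2cc(Br)ccc2oc1=O`) gives 5450 nM and compound 1 (`CCOc1ccc2nc(Cl)c(/C=N/NC(=O)c3cc4cc([N+](=O)[O-])ccc4oc3=O)cc2c1`) gives 10500 nM as its reading, so the two stand within the usual scatter of each other and neither can be ranked ahead.

Compound 3 (`O=C(N/N=C/c1cc2ccccc2nc1Cl)c1cc2cc([N+](=O)[O-])ccc2oc1=O`) departs from compound 2 by a single change, nitro in place of bromo on an aromatic carbon. Among the compounds with values here, no measured pair shows this change on its own, so the size of the step in this assay has to be judged from little evidence. Compound 1 also carries a nitro group and gives 10500 nM in that read-out, which offers no sign of a large shift. A small step toward a higher number, meaning weaker inhibition, is therefore expected, quite possibly none beyond the scatter. The estimated change is a 1.4-fold higher number from compound 2 to compound 3 (0.14 log units; within the scatter) and is expected to stay modest. In this assay the estimate for compound 3 is 7500 nM with an expected range from 2800 nM to 20000 nM as its span.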

Compound 3, half-maximal inhibitory concentration: 38800 nM
Estimate against measurement, compound 3: 5.2-fold (0.71 log units) below; measured number above the stated range.
By their numbers in this assay, from the lowest: compounds 2 and 1 (each within the scatter of the next); then compound 3.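

In this assay, putting nitro in place of bromo on this aromatic carbon, meta to a fused ring and para to a fused ring, brings a clear loss of inhibition (a 7.1-fold higher number from compound 2 to compound 3 (0.85 log units; beyond the scatter)), so the group at this position does matter on the shared core, which the first two compounds could not show. Compound 1 carries the same nitro group, and with hydrogen in place of ethoxy on an aromatic carbon the number also rises beyond the scatter (a 3.7-fold higher number from compound 1 to compound 3 (0.57 log units; beyond the scatter)), so among these compounds the nitro group alone does not set the reading, and the ethoxy position counts as well. Nothing at hand offers an explanation for either step.

The compounds shown leave open whether ethoxy would shift the number in the same direction and by a similar amount on the bromo compound, compound 2. They also leave open how an amine, a carboxylic acid or a chloro group would read on the aromatic carbon that holds bromo or nitro.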